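Swapping the Sulfur Side Chain: Phenethyl Replaces Fluorobenzyl

A few compounds are considered here, and "the series" means these few. Any claim that something is new, unique, unknown or untested is made for them only; others in the source may bear on it.

Three compounds share one core and differ only in the group carried on a saturated chain carbon bound to a sulfur. In a functional assay on MCF7 cells (Homo sapiens) for inhibition, read by MTT assay, with a stated time of 72 h (a higher number here means a weaker inhibitor, a lower number a stronger inhibitor), compound 1 `Cc1cc(Nc2cc(-c3ccccc3)[nH]n2)n2nc(SCCCc3ccccc3)nc2n1` gives 3900 nM, compound 2 `Cc1cc(Nc2cc(-c3ccccc3)[nH]n2)n2nc(SCc3csc4ccccc34)nc2n1` gives 3470 nM, and compound 3 `Cc1cc(Nc2cc(-c3ccccc3)[nH]n2)n2nc(SCc3ccc(F)cc3)nc2n1` gives 4020 nM. Compound 3 sits alongside the other two, with no gap to either beyond the scatter. Compound 4 `Cc1cc(Nc2cc(-c3ccccc3)[nH]n2)n2nc(SCCc3ccccc3)nc2n1` differs from compound 3 by benzyl in place of 4-fluorophenyl on a saturated chain carbon bound to a sulfur. Among the measured compounds shown here, the steps that bear on this change are a 1.0-fold higher number from compound 1 to compound 3 (0.01 log units; within the scatter), a 1.2-fold higher number from compound 2 to compound 3 (0.06 log units; within the scatter) and a 1.1-fold lower number from compound 1 to compound 2 (0.05 log units; within the scatter), each within the scatter, so a step of the same kind is expected: a 1.1-fold lower number from compound 3 to compound 4 (0.02 log units; within the scatter) is expected to stay within the scatter. Compound 4 is therefore estimated at 3800 nM, with a range from 2000 nM to 7200 nM.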

Compound 4, half-maximal inhibitory concentration: 2700 nM
The estimate for compound 4 lay 1.4-fold (0.15 log units) above the measured number, and the stated range covers the measured number.
By their numbers in this assay, from the lowest: compounds 4, 2, 1 and 3 (each within the scatter of the next).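

In this assay, phenethyl on the sulfur stays level with every other side chain shown: the step is small from 4-fluorobenzyl (a 1.5-fold lower number from compound 3 to compound 4 (0.17 log units; within the scatter)), from the 1-benzothiophen-3-yl group (a 1.3-fold lower number from compound 2 to compound 4 (0.11 log units; within the scatter)) and from the longer chain (a 1.4-fold lower number from compound 1 to compound 4 (0.16 log units; within the scatter)). With this fourth compound, no step among the side chains shown leaves the scatter. Nothing available gives a reason for this flat result.

On these data alone, whether an amine or a carboxylic acid at the end of this chain would move the number beyond the scatter remains open.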